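This account rests on a few compounds, and the source may have more. Where it says the series, first, only, none or still open, it means among the compounds named here.

Compound 1 `Cc1nc(N)c2c(-c3ccoc3)cn([C@@H]3O[C@H](CO)[C@@H](O)[C@H]3O)c2n1`: > 20000 nM
Compound 2 `Cc1nc(N)c2c(-c3ccsc3)cn([C@@H]3O[C@H](CO)[C@@H](O)[C@H]3O)c2n1`: > 20000 nM

In a functional assay on K562 cells (Homo sapiens), read by MTT assay, with a stated time of 72 h (a lower number here means a stronger inhibitor, a higher number a weaker inhibitor), compound 2 gives > 20000 nM, which is a limit and not a number. Compound 1 gives > 20000 nM, also a limit. The two compounds share (the limit of > 20000 nM in this assay, at which 2 of the 2 values shown sit). Within the data shown here, the only measured step is a step that the two limits leave unreadable from compound 1 to compound 2, and it swaps one ring for another.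

Compound 3 `C#Cc1cn([C@@H]2O[C@H](CO)[C@@H](O)[C@H]2O)c2nc(C)nc(N)c12` differs from compound 2 by losing the ring: ethynyl in place of thiophen-3-yl on an aromatic carbon. Among the measured compounds shown here, no measured step shows what such a change does, so only a modest gain in strength is expected. The expected change is an at least 1.6-fold lower number from compound 2 to compound 3 (0.22 log units; that floor lies within the scatter). Compound 3 is estimated at 12000 nM, within an expected range of 1500 nM to 40000 nM.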

Compound 3, half-maximal inhibitory concentration: 3290 nM
Estimate against measurement, compound 3: 3.6-fold (0.56 log units) above; the range from low to high includes it.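

Among these compounds, with ethynyl in place of a five-membered aromatic ring, this position on the shared core gives a readable number for the first time in this assay, with an at least 6.0-fold lower number from compound 2 to compound 3 (0.78 log units; beyond the scatter) and an at least 6.0-fold lower number from compound 1 to compound 3 (0.78 log units; beyond the scatter). Both steps are floors and their full size cannot be read, as each starts from a limit: the limit of > 20000 nM in this assay, at which 2 of the 3 values shown sit.

The compounds shown do not separate the effect of the triple bond from that of the loss of the ring. An ethyl group, a nitrile or an amine at this position could help to tell these apart.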